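A few compounds are considered here, and "the series" means these few. Any claim that something is new, unique, unknown or untested is made for them only; others in the source may bear on it.

Among the measured compounds shown here, in a physicochemical assay for lipophilicity (on this read-out lower numbers stand for lower lipophilicity and higher numbers for higher lipophilicity), compound 1 `CC#CCn1c(N2CCC[C@@H](N)C2)cc(=O)n(CC)c1=O` gives 0.41 and compound 2 `CC#CCn1c(N2CCC[C@@H](N)C2)cc(=O)n(CCCCCC)c1=O` gives 2.15 as the highest of the two numbers so far. Compound 3 `CC#CCn1c(N2CCC[C@@H](N)C2)cc(=O)n(CCCCCCCCCC)c1=O` differs from compound 2 by butyl in place of hydrogen on a saturated chain carbon, six bonds along the chain from an aromatic nitrogen in one place: butyl in place of hydrogen on a saturated chain carbon, six bonds along the chain from an aromatic nitrogen. For the measured compounds named here, the one measured step that bears on this is the same butyl gain, made two bonds along the chain from an aromatic nitrogen, and it shows a number 1.74 log units higher from compound 1 to compound 2 (beyond the scatter) for that change. An upward step of similar size is therefore expected in this assay with a number 1.65 log units higher from compound 2 to compound 3 (beyond the scatter) as the estimate. Compound 3 is expected at 3.8 with 3.2 to 4.4 as its likely range.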

Compound 3, partition coefficient: 3.82
Beside the measured number, compound 3's estimate is 0.02 log units below it; low and high end bracket the measured number.
By their numbers in this assay, from the lowest: compound 1; then compound 2; then compound 3.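

In this assay the butyl gain six bonds along the chain from an aromatic nitrogen still brings a number 1.67 log units higher from compound 2 to compound 3 (beyond the scatter) and so the rise has not levelled off at this chain length. Taken as one change, octyl in place of hydrogen brings a number 3.41 log units higher from compound 1 to compound 3 (beyond the scatter) in all, so the read-out here still follows chain length across the whole series shown. Nothing available explains the size of these steps. On these data alone, it remains open whether a still longer chain would keep raising the number, and how a chain ending in an amine or a carboxylic acid would read.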